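A few compounds are considered here, and "the series" means these few. Any claim that something is new, unique, unknown or untested is made for them only; others in the source may bear on it.

Working notes on the series. Compound 1 `Cc1cc(OCCCO)cc(C)c1Cl` gives 3.38 in a physicochemical assay for lipophilicity, measured as octanol-water partition; a lower number here means a more polar compound, a higher number a more lipophilic compound. Compound 2 `Cc1cc(Cl)cc(C)c1OCCCO` gives 3.72 in this assay; the difference between the cores of compound 1 and compound 2 is not broken down here. Compound 3 `Cc1cc(OCC(O)CO)cc(C)c1Cl` gives 2.42 in this assay, and the step from compound 1 to compound 3, (hydroxy in place of hydrogen on a saturated chain carbon bound to two saturated chain carbons), reads a number 0.96 log units lower from compound 1 to compound 3 (beyond the scatter).

Compound 4 `Cc1cc(Cl)cc(C)c1OCC(O)CO` is not yet measured. It differs from compound 2 by hydroxy in place of hydrogen on a saturated chain carbon bound to two saturated chain carbons, the same change as from compound 1 to compound 3. Going by the values given here, the expectation for compound 4 in this assay is therefore a number 0.96 log units lower from compound 2 to compound 4 (beyond the scatter), because the single earlier instance of this change gave a number 0.96 log units lower from compound 1 to compound 3 (beyond the scatter). Among the compounds with values here, with only one prior instance, the estimate for compound 4 carries some uncertainty: it is expected to be 2.76, with a likely range from 2.4 to 3.1.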

Compound 4, partition coefficient: 2.76
Beside the measured number, compound 4's estimate shows no gap at the digits printed; low and high end bracket the measured number.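

In this assay the change to hydroxy on a saturated chain carbon bound to two saturated chain carbons reads a number 0.96 log units lower from compound 2 to compound 4 (beyond the scatter), and on the other core it reads a number 0.96 log units lower from compound 1 to compound 3 (beyond the scatter), so the step carries from one core to the other with no difference at the digits printed. These two pairs on two cores show nothing about any further core or any other chain. No measurement here bears on why the step has this size.

The compounds shown leave open whether an amine or a carboxylic acid in place of the entering hydroxy would give a step of like size on these cores. From the compounds shown here alone, a longer chain carrying the hydroxy also remains open.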